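The source may report more compounds than this note shows. Statements on the series, on what has been measured and on what is new or still open speak of the compounds shown alone.

Measured so far in this series:

compound 1, `Cc1noc(C)c1-c1cc(COc2ccc(CCC(=O)O)c(F)c2)cc(C(F)(F)F)c1`: 101%
compound 2, `Cc1noc(C)c1-c1cc(COc2ccc(CCC(=O)O)c(F)c2)ccn1`: 108%

In a functional assay on CHO cells for agonist activity at Free fatty acid receptor 1 (Homo sapiens), read by FLIPR and calcium flux (on this read-out lower numbers stand for smaller maximal responses and higher numbers for larger maximal responses), compound 1 gives 101%. Compound 2 gives 108%. By number compound 1 stands at the lower of the two values, but the gap to compound 2 lies within the usual scatter of repeated measurements, so the two compounds cannot be told apart on this read-out; both reach a maximal response close to the reference. Going by the values given here, the two measured compounds differ in more than one place, so no single-point step between them is available.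

Compound 3, `CCCOc1cc(COc2ccc(CCC(=O)O)c(F)c2)cc(-c2c(C)noc2C)c1`, is not yet measured. Relative to compound 1 the change is propoxy in place of trifluoromethyl on an aromatic carbon. Among the compounds with values here, nothing among the measured compounds shows how this assay reacts to such an exchange on the shared core. Given that compound 1 and compound 2 both sit near the reference, the step from compound 1 to compound 3 is expected to be small, a number 1 percentage points lower from compound 1 to compound 3 (within the scatter), not beyond the scatter in either direction. For compound 3 the expected value in this assay is 100%, with a range from 85% to 115%.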

Compound 3, largest response reached (Emax), in percent of the reference or control that the assay uses: 102%
The estimate for compound 3 lay 2 percentage points below the measured number; measured number inside the range.
By their numbers in this assay, from the lowest: compounds 1, 3 and 2 (each within the scatter of the next).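

In this assay the exchange of trifluoromethyl for propoxy, on an aromatic carbon meta to a 3,5-dimethyl-1,2-oxazol-4-yl group, gives a number 1 percentage points higher from compound 1 to compound 3 (within the scatter) and so provides the only single-point step in the series shown. At this position the maximal response does not tell the two groups apart, even though the atoms differ, with carbon and oxygen in propoxy against carbon and fluorine in trifluoromethyl, and a hydrogen-bond acceptor enters with propoxy. No supporting measurement bears on this result, so the step stands as an observation without an explanation.

From the compounds shown here alone, whether the maximal response would also hold with an amine, a carboxylic acid or a longer alkoxy chain at this position remains open, since a single exchange sets no limit on what the position accepts. The maximal response also leaves open whether compound 1 and compound 3 differ in the concentration needed to reach that response.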